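From (tert-butyl)carbonyl to Acetyl

This account rests on a few compounds, and the source may have more. Where it says the series, first, only, none or still open, it means among the compounds named here.

Compound 1 `COc1ccc(C(=O)Nc2ccccc2Cl)cc1OC` gives 650 nM in an assay on isolated protein for inhibition of phosphodiesterase 4A (Sus scrofa); on this read-out lower numbers stand for stronger inhibition and higher numbers for weaker inhibition. Compound 2 `COc1ccc(C(=O)Nc2ccccc2Cl)cc1OC(=O)C(C)(C)C` reaches only the limit of this assay, > 1000000 nM.

Compound 2 therefore stands at the limit of > 1000000 nM in this assay, at which 1 of the 2 values shown sits, with no exact number known. Going by the values given here, the one measured step, an at least 1500-fold higher number from compound 1 to compound 2 (3.18 log units; beyond the scatter), came from putting (tert-butyl)carbonyl in place of methyl on an oxygen on an aromatic ring. Compound 3 `COc1ccc(C(=O)Nc2ccccc2Cl)cc1OC(C)=O` differs from compound 2 by methyl in place of tert-butyl on a carbonyl carbon, which shortens the ester but keeps it. That single step was large. For compound 3 a move back toward lower numbers is expected, though probably not all the way. Compound 3 is estimated at 30000 nM, between 2000 nM and 1000000 nM, meaning an at least 33-fold lower number from compound 2 to compound 3 (1.52 log units; beyond the scatter).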

Compound 3, half-maximal inhibitory concentration: 70000 nM
Compound 3: middle estimate off by 2.3-fold (0.37 log units), on the low side; measured number inside the range.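

With methyl in place of tert-butyl on the carbonyl carbon, the result is an at least 14-fold lower number from compound 2 to compound 3 (1.15 log units; beyond the scatter), so part of the loss goes with the tert-butyl. Yet acetyl does not restore what methyl on this oxygen gives, with a 110-fold higher number from compound 1 to compound 3 (2.03 log units; beyond the scatter), so tert-butyl alone does not account for the loss. Compound 2 stands at a limit and not at a number: the limit of > 1000000 nM in this assay, at which 1 of the 3 values shown sits.

Left open is how an ethyl group or a bare hydroxyl at this position would read in this assay. Either could help separate the part played by the carbonyl from that of the added chain.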